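A few compounds are considered here, and "the series" means these few. Any claim that something is new, unique, unknown or untested is made for them only; others in the source may bear on it.

Measured in a functional assay on MCF cells (Homo sapiens) for antiproliferative activity, with a stated time of 72 h; a higher number here means a weaker inhibitor, a lower number a stronger inhibitor:
Compound 1 `OC[C@H]1O[C@@H](n2cnc3c(NCc4cccc(F)c4)ncnc32)[C@H](O)[C@@H]1O` gives 15300 nM.
Compound 2 `OC[C@H]1O[C@@H](n2cnc3c(NCc4ccccc4Br)ncnc32)[C@H](O)[C@@H]1O` gives only a limit of the assay, > 166000 nM.

Among the measured compounds shown here, compound 1 stands as the only real number; the other value shown is a limit. For the measured compounds named here, the single measured step, an at least 10-fold higher number from compound 1 to compound 2 (1.03 log units; beyond the scatter), runs into the limit (the limit of > 166000 nM in this assay, at which 1 of the 2 values shown sits), so its size is known only as a minimum. Compound 3 `COc1cccc(CNc2ncnc3c2ncn3[C@@H]2O[C@H](CO)[C@@H](O)[C@H]2O)c1` differs from compound 1 by methoxy in place of fluoro on an aromatic carbon. Going by the values given here, no measured step changes the same group at the same place on the benzyl ring; the step to compound 2 alters both the halogen and where it sits, so it bears on compound 3 only loosely, showing that substitution on this ring can move the number far. For compound 3 the expectation is a step of a 1.0-fold lower number from compound 1 to compound 3 (0.01 log units; within the scatter), inside the usual scatter. Compound 3 is estimated at 15000 nM, between 5000 nM and 50000 nM.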

Compound 3, half-maximal inhibitory concentration: > 166000 nM
Compound 3 gave a limit, no number; the forecaster's own chance of this, stated with the estimate: 15%; middle value at least 11-fold (1.04 log units) away from the limit.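

Methoxy in place of fluoro on this aromatic carbon gives an at least 10-fold higher number from compound 1 to compound 3 (1.03 log units; beyond the scatter), and the size of that step is known only as a minimum. The earlier step to compound 2 changed both the group and its place on the ring, whereas this one changes the group alone, so a swap at this single carbon is enough to take the series from a measured number to a limit in this assay. The step between compound 2 and compound 3 cannot be read, as both values are limits of the assay: the limit of > 166000 nM in this assay, at which 2 of the 3 values shown sit.

Among the compounds shown here, with compound 1 as the only number, no trend across groups on this carbon can be drawn. From the compounds shown here alone, whether a chloro, a hydroxyl or an amine at this carbon would keep a measurable number remains open, as does how far compound 2 and compound 3 lie past the limit.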